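The compounds below may be only part of what the source reports. "The series", "measured", "known", "first", "only" and "open" are said of these compounds alone.

Measured compounds in a functional assay on U-251 cells (Homo sapiens) for inhibition, read by sulforhodamine B assay, with a stated time of 48 h; on this read-out higher numbers stand for lower toxicity in this test and lower numbers for higher toxicity in this test:

- compound 1 `COc1cc(C)cc(-c2c(-c3ccnc(-c4ccc(C(C)=O)cc4)c3)cnn2CC#N)c1`: this assay gives a limit only, > 100000 nM
- compound 2 `Cc1cc(O)cc(-c2nn(CC#N)cc2-c2ccnc(-c3ccc(N(C)C)cc3)c2)c1`: this assay gives 61300 nM

Compound 1 stands at the limit of this assay; its value is not a number (the limit of > 100000 nM in this assay, at which 1 of the 2 values shown sits). Compound 2 carries a dimethylamino group and a hydroxyl group where compound 1 carries acetyl and methoxy, and its value in this assay is a number. The two structures differ in more than one place, so only the two values themselves can be set side by side.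

Compound 3 `COc1cc(C)cc(-c2c(-c3ccnc(-c4ccc(N(C)C)cc4)c3)cnn2CC#N)c1` differs from compound 1 in one place: dimethylamino in place of acetyl on an aromatic carbon. For the measured compounds named here, no measured pair isolates this change. Compound 2, which also carries dimethylamino, gives 61300 nM, and compound 3 is expected to fall near that region. The step is expected to be an at least 1.2-fold lower number from compound 1 to compound 3 (0.09 log units; that floor lies within the scatter). The expected direction for compound 3 is toward a number rather than a limit of this assay, though a limit remains possible. Compound 3 is estimated at 80000 nM, in the range 30000 nM to 200000 nM.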

Compound 3, concentration lethal to 50% of the cells: > 100000 nM
Compound 3: only a limit was reported (the forecaster's own chance of this, stated with the estimate: 40%); at least 1.2-fold (0.09 log units) between middle value and limit.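

Compound 1 and compound 3 both give only a limit, not a number, in this assay, so no step can be read between them: the limit of > 100000 nM in this assay, at which 2 of the 3 values shown sit.

The compounds shown leave open whether dimethylamino in place of acetyl on an aromatic carbon changes the value in this assay at all.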